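A few compounds are considered here, and "the series" means these few. Any claim that something is new, unique, unknown or untested is made for them only; others in the source may bear on it.

Compound 1, `Nc1nc(N)c2nc(CCc3ccc(C(=O)NC(CCC(=O)O)C(=O)O)c4ccccc34)cnc2n1`, and compound 2, `Cc1c(CCc2ccc(C(=O)NC(CCC(=O)O)C(=O)O)c3ccccc23)cnc2nc(N)nc(N)c12`, share one core and differ at a single position, which carries a hydrogen in compound 1 and a methyl in compound 2. In a functional assay on CCRF S-180 cells (Mus musculus) for inhibition (a lower number here means a stronger inhibitor, a higher number a weaker inhibitor), compound 1 gives 1.7 nM, while compound 2 gives 29 nM. Compound 2 therefore stands at the higher of the two numbers, and its gap to compound 1 lies beyond the usual scatter of repeated measurements, so compound 2 is the weaker inhibitor of the pair.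

Compound 3, `CCc1c(CCc2ccc(C(=O)NC(CCC(=O)O)C(=O)O)c3ccccc23)cnc2nc(N)nc(N)c12`, carries the same change one bond further: methyl in place of hydrogen on a saturated chain carbon bound to an aromatic carbon. For the measured compounds named here, no measured pair shows a step of this exact kind, so its size is not known from the data and has to be estimated. Compound 2 sits at 29 nM, already the higher number, and compound 3 is expected to move only a modest step from it, most likely upward, as a 1.7-fold higher number from compound 2 to compound 3 (0.24 log units; within the scatter). The estimate for compound 3 in this assay is therefore 50 nM, with a range from 15 nM to 200 nM.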

Compound 3, half-maximal inhibitory concentration: 29 nM
Compound 3: the middle estimate sits 1.7-fold (0.24 log units) above what was measured; the range from low to high includes it.
By their numbers in this assay, from the lowest: compound 1; then compounds 2 and 3 (each within the scatter of the next).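

In this assay the change from methyl to ethyl gives no change at the digits printed from compound 2 to compound 3 (within the scatter) and so leaves the number where it was. The earlier pair showed only that a methyl in place of hydrogen at this position goes with a weaker inhibitor, with compound 1 at 1.7 nM and compound 2 at 29 nM in the same test, and that pair could not say whether one more carbon would push the number higher still; for these two compounds, at least, the extra carbon on the saturated chain carbon bound to an aromatic carbon adds nothing further to the loss seen with methyl. No measurement offered here explains why the number holds steady.

Going by these compounds, what stays open is whether this flat stretch goes on with a longer chain such as propyl, or with a branched group such as isopropyl, or whether the number starts to climb again. Also open, on these data alone, is how the position responds to a group of a different kind, such as an amine or a carboxylic acid, in place of the plain carbon chains seen so far.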